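The source may hold more compounds than are shown below. What is called first, only, known or untested is meant among the compounds shown, and "the series" means these compounds.

Of the compounds shown here, three of one series have been tested in an ADME assay on BJ cells (Homo sapiens) for cytotoxicity, read by CellTiter-Glo and resazurin assay, with a stated time of 72 h; on this read-out lower numbers stand for an effect already at smaller amounts and higher numbers for an effect only at larger amounts of compound. Compound 1, `COc1cccc(-c2ccc(C(=O)N(Cc3cccc(OCCCCCC(=O)O)c3)C(C)C)cc2)c1`, compound 2, `Cc1nnc(-c2cccc(-c3ccc(C(=O)N(Cc4cccc(OCCCCCC(=O)O)c4)C(C)C)cc3)c2)o1`, and compound 3, `CCOC(=O)CCCCCOc1cccc(CN(C(=O)c2ccc(-c3cccc(-c4nnc(C)o4)c3)cc2)C(C)C)c1`, share a core and differ at two places. In this assay compound 1 gives only a limit, > 20900 nM. Compound 2 likewise reaches only a limit, > 26000 nM. Compound 3 too is reported as a limit, > 26000 nM. Because all three values are limits, the steps between them cannot be read: a step that the two limits leave unreadable from compound 2 to compound 1, and a step that the two limits leave unreadable from compound 2 to compound 3. The evidence behind this is the limit of > 20900 nM in this assay, at which 1 of the 3 values shown sits, and (the limit of > 26000 nM in this assay, at which 2 of the 3 values shown sit).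

The change from compound 2 to compound 1 is methoxy in place of 5-methyl-1,3,4-oxadiazol-2-yl on an aromatic carbon. The cores of compound 3 and compound 2 differ by ethyl in place of hydrogen on an oxygen next to a carbonyl group.

Compound 4, `CCOC(=O)CCCCCOc1cccc(CN(C(=O)c2ccc(-c3cccc(OC)c3)cc2)C(C)C)c1`, has not yet been tested in this assay. It differs from compound 3 by methoxy in place of 5-methyl-1,3,4-oxadiazol-2-yl on an aromatic carbon, the same change as that from compound 2 to compound 1, at the same place. Since that earlier step left both compounds at a limit, compound 4 is expected to behave in the same way in this assay, and the estimated step from compound 3 to compound 4 is a step that the limit leaves unreadable from compound 3 to compound 4, resting on the limits of compound 1, compound 2 and compound 3. Compound 4 is therefore estimated at 30000 nM in this assay, with a range from 15000 nM to 100000 nM, most likely to be reported as a limit rather than a number.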

Compound 4, half-maximal effective concentration: > 21000 nM
Compound 4 ended at the assay's limit (the forecaster's own chance of this, stated with the estimate: 85%); the middle value does not contradict the limit.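

Compound 1, compound 2, compound 3 and compound 4 are all reported only as limits in this assay, so no new step can be read, neither from compound 3 to compound 4 nor from compound 1 to compound 4. The compounds shown leave open at what concentration any of the four would reach its half-maximal effect, and whether either change shifts that concentration at all.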